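Methoxy in place of hydrogen: from compound 2 to compound 3

The source may hold more compounds than are shown below. What is called first, only, known or untested is meant among the compounds shown, and "the series" means these compounds.

Compound 2 `O=C(N/N=C/c1ccccc1)Nc1ccc(Oc2ccnc3[nH]ccc23)cc1` has been measured in a functional assay on MCF7 cells (Homo sapiens) for antiproliferative activity, read by MTT assay, with a stated time of 72 h; on this read-out lower numbers stand for stronger inhibition and higher numbers for weaker inhibition; compound 2 gives 1510 nM. Of the two numbers in hand it is the smaller, but the nearest compound, compound 1 `O=C(N/N=C/c1ccccc1)Nc1ccc(Oc2ccnc3[nH]ccc23)c(F)c1`, sits within the scatter of it: compound 1 gives 2380 nM, and the step of a 1.6-fold lower number from compound 1 to compound 2 (0.20 log units; within the scatter) corresponds to hydrogen in place of fluoro on an aromatic carbon. Compound 3 `COc1ccc(/C=N/NC(=O)Nc2ccc(Oc3ccnc4[nH]ccc34)cc2)cc1` differs from compound 2 by methoxy in place of hydrogen on an aromatic carbon, para to a large group. Going by the values given here, no measured step bears directly on this change; the only step available, a 1.6-fold lower number from compound 1 to compound 2 (0.20 log units; within the scatter), is of a different kind and itself within the scatter, so it offers no basis for a shift in either direction. The expectation for compound 3 is therefore a step of a 1.0-fold lower number from compound 2 to compound 3 (0.00 log units; within the scatter), no larger than the scatter. Compound 3 is estimated at 1500 nM, with a range from 700 nM to 3200 nM.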

Compound 3, half-maximal inhibitory concentration: "not active" (no number reported)
The entry for compound 3 holds no number; there is nothing to compare the estimate with.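

Going by these compounds alone, compound 3 is entered as "not active" with no number, so no step from compound 2 to compound 3 can be read. Going by these compounds, how far phenyl to 4-methoxyphenyl moves the read-out, and in which direction, stays open. No evidence bears on this result.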